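This account rests on a few compounds, and the source may have more. Where it says the series, first, only, none or still open, it means among the compounds named here.

Compound 1 `O=C(Cn1cc(-c2ccccc2Cl)nn1)Nc1nc2ccccc2s1`: > 30000 nM
Compound 2 `O=C(Cn1cc(-c2ccncc2)nn1)Nc1nccs1`: 2 nM
Compound 3 `Cc1cc(NC(=O)Cn2cc(-c3ccc([N+](=O)[O-])cc3)nn2)no1`: 1220 nM

All three were tested in a functional assay on BMDM cells (Mus musculus, strain C57BL/6) for inhibition, with a stated time of 2 days; on this read-out higher numbers stand for weaker inhibition and lower numbers for stronger inhibition. Compound 1 stands at the limit of > 30000 nM in this assay, at which 1 of the 3 values shown sits; its result is a limit of the assay, not a measured number. Among the compounds with values here, compound 2 and compound 3 each differ from compound 1 in more than one place, so no single step links them to it. Compound 4 `O=C(Cn1cc(-c2ccc(F)cc2)nn1)Nc1nc2ccccc2s1` differs from compound 1 by 4-fluorophenyl in place of 2-chlorophenyl on an aromatic carbon. Within the data shown here, no measured step of this kind exists among the three, so the effect of swapping one halogenated phenyl for another is uncertain; the step from compound 1 to compound 4 is expected to be an at least 2.0-fold lower number from compound 1 to compound 4 (0.30 log units; that floor lies within the scatter), a gain in inhibition of modest size at most. In this assay compound 4 is estimated at 15000 nM, between 1500 nM and 60000 nM.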

Compound 4, half-maximal inhibitory concentration: > 30000 nM
Compound 4 ended at the assay's limit (the forecaster's own chance of this, stated with the estimate: 50%); middle value at least 2.0-fold (0.30 log units) from the limit.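

Compound 1 and compound 4 both end at the limit of this assay, so no step between them can be read: the limit of > 30000 nM in this assay, at which 2 of the 4 values shown sit.

Going by these compounds, whether 4-fluorophenyl in place of 2-chlorophenyl changes inhibition at all remains open.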